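A thiophen-2-yl swap on compound 1

The compounds below may be only part of what the source reports. "The series", "measured", "known", "first", "only" and "open" are said of these compounds alone.

For the measured compounds named here, in a functional assay on HCT-116 cells (Homo sapiens) for inhibition, read by sulforhodamine B assay, with a stated time of 48 h, tested at 50 uM (on this read-out higher numbers stand for more inhibition of growth at the one concentration tested and lower numbers for less inhibition of growth), compound 1 `COc1cc(/C=C/C(=O)/C=C/c2cccc3ccccc23)ccc1OCc1cn(CCCCOc2cc(=O)oc3ccccc23)nn1` gives 56%, the lower of the two numbers known so far. Compound 2 `COc1ccc(/C=C/C(=O)/C=C/c2ccc(OCc3cn(CCOc4cc(=O)oc5ccccc45)nn3)c(OC)c2)cc1OC` reaches 82%, a gap beyond the scatter. Going by the values given here, no two measured compounds differ in only one place, so no measured step can guide the next one. Compound 3 `COc1cc(/C=C/C(=O)/C=C/c2cccs2)ccc1OCc1cn(CCCCOc2cc(=O)oc3ccccc23)nn1` differs from compound 1 by having thiophen-2-yl in place of naphthalen-1-yl on a double-bonded chain carbon bound to a double-bonded chain carbon. The step expected in this assay is none beyond the scatter, an estimated a number 4 percentage points higher from compound 1 to compound 3 (within the scatter). For compound 3 the estimate is 60%, with an expected range of 40% to 80%.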

Compound 3, percent growth inhibition at one concentration: 41%
Compound 3: middle estimate off by 19 percentage points, on the high side, and the stated range covers the measured number.
By their numbers in this assay, from the lowest: compound 3; then compound 1; then compound 2.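

In this assay this position is not neutral: replacing naphthalen-1-yl, with its two six-membered aromatic rings, by thiophen-2-yl, a single five-membered aromatic ring, gives a number 15 percentage points lower from compound 1 to compound 3 (beyond the scatter). For the compounds shown here, this is the first comparison in which only one place changes, and here the group on the double-bonded chain carbon alone shifts growth inhibition. No measurement shown here gives a reason for the drop. Going by these compounds, whether a phenyl or a pyridin-3-yl group at this position would retain the inhibition of compound 1 remains open.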